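This account rests on a few compounds, and the source may have more. Where it says the series, first, only, none or still open, it means among the compounds named here.

Compound 1 `O=C1C(=O)N(CN2CCN(c3ccnc4cc(C(F)(F)F)ccc34)CC2)c2cc(Cl)ccc21` and compound 2 `O=C1C(=O)N(CN2CCN(c3ccnc4cc(C(F)(F)F)ccc34)CC2)c2cc(Br)ccc21` share one core, while compound 3 `NC(=S)N/N=C1\C(=O)Nc2cccc(Cl)c21` and compound 4 `NC(=S)N/N=C1\C(=O)Nc2cccc(Br)c21` share another; the difference between the two cores is not broken down here. In an ADME assay on 184B5 cells (Homo sapiens) for cytotoxicity, read by sulforhodamine B assay, with a stated time of 48 h (a higher number here means a weaker inhibitor of growth, a lower number a stronger inhibitor of growth), compound 1 gives 25300 nM, and compound 2 gives 21800 nM. The change between them is bromo in place of chloro on an aromatic carbon, and the step it made was a 1.2-fold lower number from compound 1 to compound 2 (0.06 log units; within the scatter). In this assay compound 3 gives 25900 nM, a number that sits with those of compound 1 and compound 2 within the usual scatter. Compound 4 is not yet measured. It differs from compound 3 by bromo in place of chloro on an aromatic carbon. Going by the values given here, this is the same kind of change as the one from compound 1 to compound 2, though the surroundings differ: in the first pair the substituted carbon is meta to a fused ring and para to a fused ring, whereas in the second pair it is ortho to a fused ring and meta to a fused ring. Because the earlier step was a 1.2-fold lower number from compound 1 to compound 2 (0.06 log units; within the scatter), the step expected for compound 4 is a 1.2-fold lower number from compound 3 to compound 4 (0.07 log units; within the scatter). Compound 4 is therefore estimated to give 22000 nM in this assay, most likely between 10000 nM and 50000 nM.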

Compound 4, concentration for 50% growth inhibition: 22600 nM
The estimate for compound 4 lay 1.0-fold (0.01 log units) below the measured number; the range from low to high includes it.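

In this assay, bromo in place of chloro on an aromatic carbon gave a 1.1-fold lower number from compound 3 to compound 4 (0.06 log units; within the scatter), and this step matches the one seen on the other core: the same change on two cores in this assay, a 1.2-fold lower number (0.06 log units; within the scatter) from compound 1 to compound 2 and a 1.1-fold lower number (0.06 log units; within the scatter) from compound 3 to compound 4, 1.0-fold (0.01 log units) apart, within the scatter of two such steps For these two pairs, then, the change carried from one core to the other with the same outcome, even though the substituted carbon in compound 3 and compound 4 is ortho to a fused ring and meta to a fused ring. This does not show that the two cores respond alike in general: each step lies within the scatter, so the agreement is between two steps that cannot be told from no change, and it rests on a single change in a single assay.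

The compounds shown carry only chloro or bromo at the substituted carbon, so it remains open whether hydrogen, fluoro, methoxy or an amine there would give a larger step. As far as these compounds go, it also remains open whether any such step would carry from one core to the other.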